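The compounds below may be only part of what the source reports. "The series", "measured", "known", "first", "only" and "open" are said of these compounds alone.

Compound 1 `COc1ccc2c(=O)c(/C=C/C(=O)Nc3cccc(Cl)c3)coc2c1`: 11900 nM; compound 2 `COc1ccc2c(=O)c(/C=C/C(=O)NCc3ccccc3)coc2c1`: 33400 nM; compound 3 `COc1cccc(NC(=O)/C=C/c2coc3cc(OC)ccc3c2=O)c1`: 19200 nM.

In a functional assay on HeLa cells (Homo sapiens) for inhibition, read by MTT assay, with a stated time of 48 h (on this read-out higher numbers stand for weaker inhibition and lower numbers for stronger inhibition), compound 2 gives the highest number of the three. Its gap to compound 3 is small, a 1.7-fold lower number from compound 2 to compound 3 (0.24 log units; within the scatter), while the gap to compound 1 is larger, a 2.8-fold higher number from compound 1 to compound 2 (0.45 log units; beyond the scatter). Compound 4 `COc1ccc2c(=O)c(/C=C/C(=O)Nc3ccccc3OC)coc2c1` has not been measured; it differs from compound 2 in one place: 2-methoxyphenyl in place of benzyl on an amide-type nitrogen. Both measured steps that swap benzyl for an aryl group on that nitrogen point towards lower numbers, one within the scatter and one beyond it. Within the data shown here, no measured compound carries a 2-methoxyphenyl group, so that part of the change is untested. Compound 4 is expected to move modestly, a 1.9-fold lower number from compound 2 to compound 4 (0.27 log units; within the scatter). Compound 4 is estimated at 18000 nM, between 8000 nM and 45000 nM.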

Compound 4, half-maximal inhibitory concentration: > 100000 nM
Compound 4 gave a limit, no number; the forecaster's own chance of this, stated with the estimate: 5%; at least 5.5-fold (0.74 log units) between middle value and limit.
By their numbers in this assay, from the lowest: compounds 1, 3 and 2 (each within the scatter of the next, the first and the last beyond it). At a limit, above all of these: compound 4.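

In this assay, compound 4 gives a limit and not a number: the limit of > 100000 nM in this assay, at which 1 of the 4 values shown sits. Putting an aryl group in place of benzyl on the amide-type nitrogen therefore does not always lower the number, as 2-methoxyphenyl gives an at least 2.9-fold higher number from compound 2 to compound 4 (0.47 log units; beyond the scatter). The choice of aryl group matters too: 2-methoxyphenyl in place of 3-methoxyphenyl gives an at least 5.2-fold higher number from compound 3 to compound 4 (0.71 log units; beyond the scatter), and in place of 3-chlorophenyl it gives an at least 8.4-fold higher number from compound 1 to compound 4 (0.92 log units; beyond the scatter).

The limit leaves the full size of these steps open. Also open, on these data alone, is how an unsubstituted phenyl group or a pyridine ring on that nitrogen would compare.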